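Trimming a Side Chain in a Cathepsin S Inhibitor Series

The source may report more compounds than this note shows. Statements on the series, on what has been measured and on what is new or still open speak of the compounds shown alone.

Of the compounds shown here, three have been tested in an assay on isolated protein for inhibition of cathepsin S (Homo sapiens); a lower number here means a stronger inhibitor, a higher number a weaker inhibitor. Compound 1 `O=C(N[C@@H](CCc1ccccc1)CNc1ccc(OC(F)(F)F)cc1)[C@@H](CC(=O)N1CCOCC1)CC1CCCCC1` gives 18 nM. Compound 3 `CC(C)[C@@H](CNc1ccc(OC(F)(F)F)cc1)NC(=O)[C@H](CCCc1ccccc1)CC(=O)N1CCOCC1` gives 14 nM, and compound 2 `C[C@@H](CNc1ccc(OC(F)(F)F)cc1)NC(=O)[C@@H](CC(=O)N1CCOCC1)CC1CCCC1` gives 31 nM. Among these three numbers compound 1 has the second highest, but its gap to compound 3 and its gap to compound 2 both lie within the usual scatter of this assay, so the three compounds cannot be told apart on potency.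

Compound 4 `CC[C@@H](CNc1ccc(OC(F)(F)F)cc1)NC(=O)[C@@H](CC(=O)N1CCOCC1)CC1CCCCC1` is not yet measured. It differs from compound 1 in a single place: hydrogen in place of phenyl on a saturated chain carbon, three bonds along the chain from an amide-type nitrogen. The rest of the shared core, including the morpholine amide, the cyclohexylmethyl group and the trifluoromethoxy-substituted aniline, is unchanged.

Compound 2 carries a methyl at this same position, together with a smaller ring elsewhere, and its value 31 nM sits close to that of compound 1, which suggests that this part of the molecule tolerates a shorter chain. A step from compound 1 to compound 4 of a 1.7-fold higher number from compound 1 to compound 4 (0.22 log units; within the scatter) is therefore expected, a modest weakening that may not exceed the scatter. For compound 4 an inhibition constant of 30 nM is estimated, within a range from 12 nM to 80 nM.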

Compound 4, inhibition constant: 16 nM
Compound 4: middle estimate off by 1.9-fold (0.27 log units), on the high side; the range from low to high includes it.
By their numbers in this assay, from the lowest: compounds 3, 4, 1 and 2 (each within the scatter of the next, the first and the last beyond it).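

Cutting the phenethyl back to ethyl gives a 1.1-fold lower number from compound 1 to compound 4 (0.05 log units; within the scatter) in this assay, so the loss of a phenyl of 6 heavy atoms, with its six-membered aromatic ring, leaves no readable difference in inhibition of the enzyme. Among these compounds, the earlier compounds could not show this, since no two of them differ in one place only, whereas compound 1 and compound 4 share everything except this group and so give the first direct reading at this position. No supporting data bear on why the phenyl can be replaced by hydrogen here without a readable difference.

This single pair says nothing about groups of a different kind at this position, such as an amine or a carboxylic acid at the end of the ethyl chain, or a longer chain carrying a hydroxyl group. It also leaves open whether the same swap would read the same way with another ring in place of the cyclohexylmethyl group, or with another group in place of the morpholine amide.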